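The compounds below may be only part of what the source reports. "The series", "measured", "known", "first", "only" and "open" are said of these compounds alone.

Compound 2 (`O=C(CCCCCCCc1ccccc1)N[C@H]1CCOC1=O`) is read in a functional assay on NCI-H630 cells (Homo sapiens) for cytotoxicity, read by sulforhodamine B assay, with a stated time of 5 days (a higher number here means a weaker inhibitor, a lower number a stronger inhibitor), and gives > 100000 nM as a limit of the assay, not a number. Compound 1 (`O=C(CCCCCc1ccccc1)N[C@H]1CCOC1=O`) likewise gives > 100000 nM as a limit. Compound 3 (`O=C(CCCCCCCCCc1ccccc1)CC(=O)N[C@@H]1CCOC1=O`) also gives > 100000 nM as a limit. For the measured compounds named here, the series so far therefore amounts to the limit of > 100000 nM in this assay, at which 3 of the 3 values shown sit, and offers no numerical value to rank, and no measured step to size a change.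

Compound 4 (`O=C(CCCCCCCCc1ccccc1)N[C@H]1CCOC1=O`) differs from compound 2 by benzyl in place of phenyl on a saturated chain carbon, seven bonds along the chain from a carbonyl carbon with benzyl in place of phenyl on a saturated chain carbon, seven bonds along the chain from a carbonyl carbon.

With compound 2 at the limit of > 100000 nM as the only anchor, no shift beyond the scatter is expected in this assay and no direction is favoured. Going by the values given here, the expected change is a number no higher from compound 2 to compound 4 (the limit leaves the size open) and amounts to no real step. Compound 4 is estimated at 100000 nM with an expected range of 50000 nM to 200000 nM and a report as a limit is the likeliest outcome.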

Compound 4, half-maximal inhibitory concentration: > 100000 nM
Compound 4: only a limit was reported (the forecaster's own chance of this, stated with the estimate: 85%); the middle value lies on the limit itself.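

Compound 2 and compound 4 yield no readable step for benzyl in place of phenyl, because both results are limits and not numbers: the limit of > 100000 nM in this assay, at which 4 of the 4 values shown sit.

The compounds shown leave open whether any member of this series reaches a measurable value in this assay.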